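Series notes: ethyl in place of ethoxy, compound 3

The source may hold more compounds than are shown below. What is called first, only, known or untested is meant among the compounds shown, and "the series" means these compounds.

All numbers come from a functional assay (spleen, spleen) for activation, with Mus musculus as the target; a lower number here means that less compound is needed, a higher number that more compound is needed for the effect. Compound 1 `Cc1nc(N)c2nc(O)n(Cc3ccccc3)c2n1` gives 1 uM. Among the measured compounds shown here, compound 2 `CCOc1nc(N)c2nc(O)n(Cc3ccccc3)c2n1` gives 0.1 uM, the lowest of the two numbers so far; its only neighbour is compound 1, and the single measured step, a 10-fold lower number from compound 1 to compound 2 (1.00 log units; beyond the scatter), separates the pair.

Compound 3 `CCc1nc(N)c2nc(O)n(Cc3ccccc3)c2n1` is not yet measured. It differs from compound 2 by ethyl in place of ethoxy on an aromatic carbon. For the measured compounds named here, no measured step compares ethyl with either ethoxy or methyl, so the change cannot be read off directly. Going by the values given here, the one step that bears on it is a 10-fold lower number from compound 1 to compound 2 (1.00 log units; beyond the scatter), which shows that the group on this aromatic carbon matters well beyond the scatter. Compound 3 keeps the two-carbon chain of the ethoxy group but loses the oxygen that the counted difference removes, so the number is expected to move back toward that of compound 1, though not necessarily all the way. The expected step is a 4.0-fold higher number from compound 2 to compound 3 (0.60 log units; beyond the scatter). Compound 3 is estimated at 0.4 uM, with a range of 0.1 uM to 2 uM.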

Compound 3, minimum effective concentration: 1 uM
Compound 3: middle estimate off by 2.5-fold (0.40 log units), on the low side; measured number inside the range.
By their numbers in this assay, from the lowest: compound 2; then compounds 1 and 3 (each within the scatter of the next).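

Going from ethoxy to ethyl on this aromatic carbon, with the two-carbon chain kept, gives in this assay a 10-fold higher number from compound 2 to compound 3 (1.00 log units; beyond the scatter), so among these compounds the lower number goes with ethoxy and not with the chain length alone. Methyl in place of hydrogen on the saturated chain carbon bound to the aromatic carbon gives no change at the digits printed from compound 1 to compound 3 (within the scatter), so methyl and ethyl cannot be told apart at this position and the ethoxy of compound 2 stands alone among the three groups compared. Among the compounds shown here, the numbers show only that the oxygen-linked group differs from the two carbon-linked ones, and nothing measured here gives a reason for that difference.

The compounds shown leave open whether the lower number belongs to oxygen-linked groups in general or to ethoxy alone, a question that methoxy, butoxy or a longer alkoxy chain on the same aromatic carbon would address. They also leave open whether another linking atom would behave like the oxygen of compound 2, as in an ethylamino or an ethylthio group, or whether a longer alkyl chain such as butyl would stay level with compound 3.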